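A Leucine-Type Side Chain in Place of Asparagine

The source may report more compounds than this note shows. Statements on the series, on what has been measured and on what is new or still open speak of the compounds shown alone.

Of the compounds shown here, three built on a shared core have been measured in a functional assay on the whole organism (Tail, strain ICR) with Mus musculus as the target, in the tail flick test, with a stated time of 30 min, at a dose of 25 umol/kg by the oral route; a higher number here means a stronger effect of the compound at the dose given, a lower number a weaker effect. Compound 1 `NC(=O)C[C@H](NC(=O)CN(c1nc(Cl)nc2[nH]cnc12)C1CC1)C(=O)O` gives 29.7%, which is the second highest of the three numbers. Compound 2 `C[C@@H](O)[C@H](NC(=O)CN(c1ncnc2c1ncn2C1CCCCO1)C1CC1)C(=O)OCc1ccccc1` gives 23.6%, a number that lies within the usual scatter of the value for compound 1. Compound 3 `CC[C@H](C)[C@H](NC(=O)CN(c1nc(Cl)nc2[nH]cnc12)C1CC1)C(=O)OCc1ccccc1` gives 41.4%, which stands beyond the scatter above compound 1.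

Compound 4 `CC(C)C[C@H](NC(=O)CN(c1nc(Cl)nc2[nH]cnc12)C1CC1)C(=O)O` is the next step from compound 1 and has not yet been measured. The change is a single one: isopropyl in place of carbamoyl on a saturated chain carbon, two bonds along the chain from an amide-type nitrogen and a carbonyl carbon. A carbamoyl group, with one hydrogen-bond donor and one acceptor, gives way to an isopropyl group that has neither.

Within the data shown here, no measured pair shows this exact change, so the expected size of the step rests on compound 3, whose branched alkyl side chain goes with the value 41.4%. On that basis a modest rise is expected, and the step of a number 6.3 percentage points higher from compound 1 to compound 4 (within the scatter) is estimated to land near the edge of the scatter. Compound 4 is expected to give 36%, with a plausible range from 22% to 50%.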

Compound 4, a percentage reported as activity, at one dose (the size of the read-out at that dose, not a potency): 23.4%
Compound 4: the middle estimate sits 12.6 percentage points above what was measured; the measured number falls inside the stated range.
By their numbers in this assay, from the lowest: compounds 4, 2 and 1 (each within the scatter of the next); then compound 3.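

In this assay, isopropyl in place of carbamoyl on this saturated chain carbon comes out as a number 6.3 percentage points lower from compound 1 to compound 4 (within the scatter). At this position, then, carbamoyl with its hydrogen-bond donor and acceptor can give way to an isopropyl group that has neither, without the read-out at this dose moving beyond the scatter. Nothing measured here says why the read-out responds this way.

As far as these compounds go, whether an amine or a longer alkyl chain on this same carbon would move the number beyond the scatter remains open. A read-out at a single dose and a single time also leaves open whether compound 1 and compound 4 would still match at other doses or times.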